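The compounds below may be only part of what the source reports. "The series", "measured", "known", "first", "only" and "open" are said of these compounds alone.

Working notes on the series. Among the measured compounds shown here, compound 1 `COc1ccc2[nH]c3c(c2c1)CCNC31CCN(Cc2ccc([N+](=O)[O-])cc2F)CC1` gives 5900 nM in an assay on FRT cells for positive allosteric modulation of Cystic fibrosis transmembrane conductance regulator variant N1303K (Homo sapiens), in the presence of a further agent that is not named here (a higher number here means that more compound is needed for the effect, a lower number that less compound is needed), and stands second highest of the three numbers so far. Compound 2 `COc1ccc2[nH]c3c(c2c1)CCNC31CCN(Cc2cc(Cl)ccc2[N+](=O)[O-])CC1` gives 7100 nM in this assay, and the step of a 1.2-fold higher number from compound 1 to compound 2 (0.08 log units; within the scatter) is within the scatter. Compound 3 `COc1ccc2[nH]c3c(c2c1)CCNC31CCN(Cc2ccc(Br)c(F)c2)CC1` gives 1800 nM, with the step of a 3.3-fold lower number from compound 1 to compound 3 (0.52 log units; beyond the scatter) and, from the other nitrophenyl compound, a 3.9-fold lower number from compound 2 to compound 3 (0.60 log units; beyond the scatter).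

Compound 4 `COc1ccc2[nH]c3c(c2c1)CCNC31CCN(Cc2cc(F)c(F)c(F)c2)CC1` is not yet measured. It differs from compound 1 as follows: 3,4,5-trifluorophenyl in place of 2-fluoro-4-nitrophenyl on a saturated chain carbon bound to an amine nitrogen in a ring. For the measured compounds named here, the step that bears most directly on it is the one from compound 1 to compound 3, where a ring bearing only halogens replaced the nitrophenyl ring and the number fell modestly; the step from compound 2 to compound 3 shows the same direction. Compound 4 also carries a ring bearing only fluorine substituents, so a modest decrease is expected, of about the size seen for compound 3, as a 2.6-fold lower number from compound 1 to compound 4 (0.41 log units; beyond the scatter). The estimate for compound 4 is 2300 nM, with a range from 900 nM to 6000 nM.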

Compound 4, half-maximal effective concentration: 2600 nM
For compound 4 the middle estimate is 1.1-fold (0.05 log units) below the measured one, within the range that was stated.
By their numbers in this assay, from the lowest: compounds 3 and 4 (each within the scatter of the next); then compounds 1 and 2 (each within the scatter of the next).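

In this assay, a second ring bearing only halogens, here 3,4,5-trifluorophenyl, also gives a lower number than the nitrophenyl rings (a 2.3-fold lower number from compound 1 to compound 4 (0.36 log units; beyond the scatter)) and (a 2.7-fold lower number from compound 2 to compound 4 (0.44 log units; beyond the scatter)). The earlier drop therefore does not rest on compound 3 alone, and at this place, on a saturated chain carbon bound to an amine nitrogen in a ring, bromine is not required for it. The two halogen-only rings cannot be told apart (a 1.4-fold higher number from compound 3 to compound 4 (0.16 log units; within the scatter)), so neither the number of fluorines nor the swap of bromine for fluorine shows an effect in this pair.

No supporting data are available to explain why these ring changes shift the number. Open, as far as these compounds go, is how an unsubstituted phenyl, or a phenyl ring carrying a methoxy group, an amine or a carboxylic acid, would compare at this place.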